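The source may hold more compounds than are shown below. What is called first, only, known or untested is meant among the compounds shown, and "the series" means these compounds.

Compound 3 (`COc1cc(OC)c(Cl)c(-c2ccc3c(NC(=O)c4ccccc4)n[nH]c3n2)c1Cl`) stands only at a limit in a functional assay on NCI-H1581 cells (Homo sapiens) for antiproliferative activity, read by CCK-8 assay, with a stated time of 72 h (on this read-out higher numbers stand for weaker inhibition and lower numbers for stronger inhibition), > 1000 nM. Compound 4 (`COc1cc(OC)c(Cl)c(-c2ccc3c(NC(=O)c4ccc(N(C)C)cc4)n[nH]c3n2)c1Cl`) differs from it by one change, dimethylamino in place of hydrogen on an aromatic carbon, para to a large group. Compound 1 (`COc1cc(OC)c(Cl)c(-c2ccc3c(NC(=O)c4ccc(N5CCCCC5)cc4)n[nH]c3n2)c1Cl`) gives 558 nM. The closest measured step is an at least 1.7-fold higher number from compound 1 to compound 3 (0.25 log units; that floor lies within the scatter), which takes piperidin-1-yl away. The large at least 270-fold higher number from compound 2 to compound 3 (2.43 log units; beyond the scatter) starts from compound 2 (`COc1cc(OC)c(Cl)c(-c2ccc3c(NC(=O)c4ccc(N5CCN(C)CC5)s4)n[nH]c3n2)c1Cl`), at 3.7 nM, and like a 150-fold lower number from compound 1 to compound 2 (2.18 log units; beyond the scatter) it exchanges the whole group on the carbonyl carbon, so it bears little on this change. The step expected is an at least 1.4-fold lower number from compound 3 to compound 4 (0.15 log units; that floor lies within the scatter), modest and toward a lower number. Compound 4 is estimated at 700 nM, within a range of 250 nM to 2000 nM.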

Compound 4, half-maximal inhibitory concentration: 294 nM
Compound 4: middle estimate off by 2.4-fold (0.38 log units), on the high side; measured number inside the range.
By their numbers in this assay, from the lowest: compound 2; then compounds 4 and 1 (each within the scatter of the next). At a limit, above all of these: compound 3.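

With an at least 3.4-fold lower number from compound 3 to compound 4 (0.53 log units; beyond the scatter), dimethylamino in place of hydrogen gives a step beyond the scatter, which the floor for piperidin-1-yl did not, though this comparison rests on compound 3 standing only at a limit: the limit of > 1000 nM in this assay, at which 1 of the 4 values shown sits. The two amines cannot be told apart at this place, with a 1.9-fold lower number from compound 1 to compound 4 (0.28 log units; within the scatter). Exchanging the whole group on the carbonyl carbon still matters far more, with a 79-fold higher number from compound 2 to compound 4 (1.90 log units; beyond the scatter).

From the compounds shown here alone, whether 4-methylpiperazin-1-yl at this place on the phenyl ring would close that gap remains open. So does the effect of a morpholine there.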